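This account rests on a few compounds, and the source may have more. Where it says the series, first, only, none or still open, it means among the compounds named here.

Of the compounds shown here, two built on one shared core have so far been tested in a functional assay on NCI-H460 cells (Homo sapiens) for cytotoxicity, read by MTT assay, with a stated time of 48 h; a higher number here means a weaker inhibitor, a lower number a stronger inhibitor. Compound 1 `C=C1C(=O)O[C@H]2CC3=C[C@H](C/C(C)=C/[C@@H](OC(=O)C4CCC(F)(F)CC4)[C@H]12)OC3=O` reads > 10000 nM, which is a limit of the assay and not a number. Going by the values given here, compound 2 `C=C1C(=O)O[C@H]2CC3=C[C@H](C/C(C)=C/[C@@H](OC(=O)/C=C/c4cccs4)[C@H]12)OC3=O` gives 2900 nM, the only true number available so far.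

Compound 3 `C=C1C(=O)O[C@H]2CC3=C[C@H](C/C(C)=C/[C@@H](OC(=O)/C=C/c4ccncc4)[C@H]12)OC3=O` differs from compound 2 in one place, with pyridin-4-yl in place of thiophen-2-yl on a double-bonded chain carbon bound to a double-bonded chain carbon.

Among the compounds with values here, only one measured step is available as a guide, and it is a loose one. Within the data shown here, that step, an at least 3.4-fold lower number from compound 1 to compound 2 (0.53 log units; beyond the scatter), replaced the whole 4,4-difluorocyclohexyl group with 2-(thiophen-2-yl)ethenyl, whereas the new change exchanges only one aromatic ring for another and leaves the ethenyl chain in place. It shows that the group on the carbonyl carbon can move the number in this assay, but it does not say which way this smaller exchange will go.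

No shift beyond the scatter is therefore expected, and the estimated step is a 1.4-fold higher number from compound 2 to compound 3 (0.14 log units; within the scatter). For compound 3 the estimated value is 4000 nM, with an expected range from 1300 nM to 10000 nM.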

Compound 3, half-maximal inhibitory concentration: 2100 nM
Compound 3: the middle estimate sits 1.9-fold (0.28 log units) above what was measured, within the range that was stated.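

In this assay, putting pyridin-4-yl in place of thiophen-2-yl gives a 1.4-fold lower number from compound 2 to compound 3 (0.14 log units; within the scatter), so a five-membered and a six-membered aromatic ring, each with one hetero atom, cannot be told apart at this place. The second ring also stands clear of the saturated group, as 2-(pyridin-4-yl)ethenyl in place of 4,4-difluorocyclohexyl on a carbonyl carbon gives an at least 4.7-fold lower number from compound 1 to compound 3 (0.67 log units; beyond the scatter), so the earlier gain is not tied to thiophen-2-yl alone. Compound 1 reads as a limit and not a number, and the size of this step is open-ended because of that: the limit of > 10000 nM in this assay, at which 1 of the 3 values shown sits.

The 4,4-difluorocyclohexyl group differs from both ethenyl groups in its ring and in its chain at once, so these compounds leave open whether the gain comes from the ethenyl chain, from the aromatic ring, or from the two together. They also leave open how a plain phenyl ring, or a pyridine ring carrying an amine or a carboxylic acid, would read in the same place, and so whether the ring can be changed further without moving the number beyond the scatter.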